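This account rests on a few compounds, and the source may have more. Where it says the series, first, only, none or still open, it means among the compounds named here.

Working notes on the series. Two compounds of the shared core have a number in an ADME assay on PANC-1 cells (Homo sapiens) for cytotoxicity, read by sulforhodamine B assay, with a stated time of 48 h, tested at 10 uM (on this read-out lower numbers stand for less inhibition and higher numbers for more inhibition at the one concentration tested (going by the name of the read-out)), so far. Compound 1 `COc1nc2ccc(Br)cc2cc1C(c1ccccc1)n1cc(-c2ccccc2)nn1` gives 30.1%. Compound 2 `COc1nc2ccc(Br)cc2cc1C(c1ccccc1)n1cc(CCCO)nn1` gives 25.5%. The one step between them, a number 4.6 percentage points lower from compound 1 to compound 2 (within the scatter), leaves the two numbers level: compound 2 stands within the scatter of compound 1, and no order between the two can be read from the numbers shown.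

The next member, compound 3 `COc1nc2ccc(Br)cc2cc1C(c1ccccc1)n1cc(-c2ccccc2C(F)(F)F)nn1`, is not yet measured in this assay. It differs from compound 2 in one place, (2-(trifluoromethyl)phenyl in place of 3-hydroxypropyl on an aromatic carbon). Within the data shown here, the only measured step that bears on this change is the step from compound 1 to compound 2, which swapped a phenyl for the 3-hydroxypropyl and stayed within the scatter. Among the measured compounds shown here, the return to a phenyl-type group is therefore not expected to move the read-out beyond the scatter; the trifluoromethyl on that phenyl has no precedent, so nothing is known of its own effect. For compound 3 the expected step is a number 4.5 percentage points higher from compound 2 to compound 3 (within the scatter). Compound 3 is therefore estimated at 30%, within 15% to 45%.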

Compound 3, a percentage reported as inhibition, at one concentration (the size of the read-out at that concentration, not a potency): 11.4%
The estimate for compound 3 lay 18.6 percentage points above the measured number; the whole stated range lies above it.
By their numbers in this assay, from the lowest: compound 3; then compounds 2 and 1 (each within the scatter of the next).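

In this assay this position, on the five-membered aromatic ring with 3 nitrogen, now gives a step beyond the scatter, which the earlier pair did not show: the change to 2-(trifluoromethyl)phenyl from 3-hydroxypropyl gives a number 14.1 percentage points lower from compound 2 to compound 3 (beyond the scatter). The closer comparison keeps the phenyl and adds only a trifluoromethyl on it, and it gives a number 18.7 percentage points lower from compound 1 to compound 3 (beyond the scatter), so within these three compounds the lower number goes with the added trifluoromethyl and not with the aromatic ring alone, as compound 1 with its phenyl and compound 2 with its chain stand level. No measurement here bears on the reason for this result, and the numbers alone do not supply one.

Still open, going by these compounds, is whether the lower number is specific to trifluoromethyl, or whether a methyl group, a chlorine or a methoxy group on the same phenyl would go with a similar step. The compounds shown also leave open how an amine, a carboxylic acid or a longer chain at this position would compare with the 3-hydroxypropyl of compound 2.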